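A few compounds are considered here, and "the series" means these few. Any claim that something is new, unique, unknown or untested is made for them only; others in the source may bear on it.

Compound 1, `Cn1c(=O)cnn(-c2ccc(Cl)c(C(=O)NCC3(O)CCCCCC3)c2)c1=O`, is the starting point. For the measured compounds named here, in a functional assay on cells for antagonist activity at P2X purinoceptor 7 (Homo sapiens), read by ELISA (a lower number here means a stronger inhibitor, a higher number a weaker inhibitor), compound 1 gives 42 nM, and among the two values shown it is the only one that is a number. Compound 2, `O=C(NCC1CCOCC1)c1cc(-n2ncc(=O)[nH]c2=O)ccc1Cl`, has a different amine side on its amide. In this assay compound 2 reaches only > 5000 nM, which is a limit of the assay and not a number. That value sits at the limit of > 5000 nM in this assay, at which 1 of the 2 values shown sits. Compound 3, `CCn1c(=O)cnn(-c2ccc(Cl)c(C(=O)NCC3(O)CCCCCC3)c2)c1=O`, has not yet been tested in this assay. The change from compound 1 to compound 3 is methyl in place of hydrogen on a saturated chain carbon bound to an aromatic nitrogen. Going by the values given here, no pair of measured compounds isolates a change of this kind, so the size of the step cannot be read off and has to be estimated. Such a small addition is expected to leave potency close to where compound 1 stands, with a step of a 1.2-fold higher number from compound 1 to compound 3 (0.08 log units; within the scatter), which lies within the usual scatter. Compound 3 is therefore estimated at 50 nM, within a range from 15 nM to 170 nM.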

Compound 3, half-maximal inhibitory concentration: 86 nM
Compound 3: the middle estimate sits 1.7-fold (0.24 log units) below what was measured, within the range that was stated.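

Going from methyl to ethyl on the aromatic nitrogen gives the first measured step at this position in this assay: a 2.0-fold higher number from compound 1 to compound 3 (0.31 log units; beyond the scatter). This step lies just beyond the scatter, so the position is not entirely indifferent to this change, although adding one carbon costs only a modest amount of potency. Nothing shown here explains this small loss.

One step in one direction cannot show whether the number keeps rising with a longer chain, such as propyl, or with a branched group, such as isopropyl, in place of the ethyl. Going by these compounds, it also remains open whether the same change would have a similar effect with a different amine side on the amide.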